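Isopropyl on the amide nitrogen of compound 2

The source may report more compounds than this note shows. Statements on the series, on what has been measured and on what is new or still open speak of the compounds shown alone.

In a functional assay on NCI-H1975 cells (Homo sapiens) for inhibition, read by sulforhodamine B assay, with a stated time of 48 h (a lower number here means a stronger inhibitor of growth, a higher number a weaker inhibitor of growth), compound 2 `CC(C)c1cc(C(=O)Nc2ccc(NC(=O)CCCCCCC(=O)NO)cc2)c(O)cc1O` stands at > 10000 nM, which is a limit of the assay and not a number. Compound 1 `CCN(C(=O)c1cc(C(C)C)c(O)cc1O)c1ccc(NC(=O)CCCCCCC(=O)NO)cc1`, which carries ethyl on that nitrogen, gives 1380 nM. Compound 3 `CC(C)c1cc(C(=O)N(c2ccc(NC(=O)CCCCCCC(=O)NO)cc2)C(C)C)c(O)cc1O` differs from compound 2 by isopropyl in place of hydrogen on an amide-type nitrogen. Among the measured compounds shown here, only one measured step bears on this change: an at least 7.2-fold higher number from compound 1 to compound 2 (0.86 log units; beyond the scatter), with hydrogen in place of ethyl on an amide-type nitrogen. Read in reverse, it leads to the expectation of a move of similar size towards a lower number in this assay. For the measured compounds named here, no isopropyl compound has been measured yet, and the starting point is only a limit, so the size remains loose. The expected step is an at least 6.6-fold lower number from compound 2 to compound 3 (0.82 log units; beyond the scatter). For compound 3 the estimated value is 1500 nM, with an expected range of 450 nM to 6000 nM.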

Compound 3, concentration for 50% growth inhibition: > 10000 nM
Compound 3 gave a limit, no number; the forecaster's own chance of this, stated with the estimate: 15%; at least 6.6-fold (0.82 log units) between middle value and limit.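

Lengthening the ethyl on the amide-type nitrogen by one methyl, which makes it isopropyl, gives an at least 7.2-fold higher number from compound 1 to compound 3 (0.86 log units; beyond the scatter) in this assay. So carrying a group on this nitrogen is not enough for a readable growth-inhibition value: among these three compounds only the ethyl of compound 1 gives one, and a single added methyl separates it from compound 3, whose value is only a limit of the assay. The step from hydrogen to isopropyl cannot be read, because compound 2 and compound 3 both sit at the same limit: the limit of > 10000 nM in this assay, at which 2 of the 3 values shown sit.

As far as these compounds go, it remains open whether methyl or an unbranched propyl chain on this nitrogen would give a readable value like that of compound 1, 1380 nM. From the compounds shown here alone, how far compound 2 and compound 3 lie beyond their limit also stays unknown.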